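This account rests on a few compounds, and the source may have more. Where it says the series, first, only, none or still open, it means among the compounds named here.

Measured so far in an ADME assay on the whole organism (strain Sprague-Dawley) for pharmacokinetics, with Rattus norvegicus as the target, using cassette dosing; a higher number here means faster removal of the compound, a lower number slower removal:
Compound 1 `O=c1[nH]c2ccc(-c3cc(C[C@]4(O)CC[C@@H](Cc5ccccc5)CC4)no3)cc2o1`: 12.1 mL/min/kg
Compound 2 `O=c1ccc(-c2cc(C[C@]3(O)CC[C@@H](Cc4ccccc4)CC3)no2)c[nH]1`: 37.6 mL/min/kg
Compound 3 `O=c1ccc(-c2cc(C[C@]3(O)CC[C@@H](Cc4ccc(Cl)cc4)CC3)no2)c[nH]1`: 16.8 mL/min/kg

Of these three, compound 2 has the highest number, at 37.6 mL/min/kg. Compound 4 `O[C@]1(Cc2cc(-c3cn[nH]c3)on2)CC[C@H](Cc2ccccc2)CC1` has not yet been measured. It differs from compound 2 in one place: a group of 5 heavy atoms (3 carbon, 2 nitrogen; one five-membered aromatic ring with 2 hetero atoms) in place of a group of 7 heavy atoms (5 carbon, 1 nitrogen, 1 oxygen; one six-membered aromatic ring with 1 hetero atom), on an aromatic carbon. The 1H-pyrazol-4-yl group enters on an aromatic carbon of a five-membered aromatic ring with 1 nitrogen and 1 oxygen.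

Within the data shown here, two measured steps bear on this change. The closer one is a 3.1-fold higher number from compound 1 to compound 2 (0.49 log units; beyond the scatter), a modest step at the same place. The other is a 2.2-fold lower number from compound 2 to compound 3 (0.35 log units; beyond the scatter), also modest, but at another place. Among the measured compounds shown here, no measured compound carries the 1H-pyrazol-4-yl group, and the data fix no direction for it. In this assay, a step no larger than these two is therefore expected, most likely none beyond the scatter. The expected step is a 1.1-fold higher number from compound 2 to compound 4 (0.03 log units; within the scatter). For compound 4 the estimated clearance is 40 mL/min/kg, with an expected range of 20 mL/min/kg to 75 mL/min/kg.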

Compound 4, clearance: 56.5 mL/min/kg
Beside the measured number, compound 4's estimate is 1.4-fold (0.15 log units) below it, within the range that was stated.
By their numbers in this assay, from the lowest: compounds 1 and 3 (each within the scatter of the next); then compounds 2 and 4 (each within the scatter of the next).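

In this assay, replacing the six-membered ring group with 1H-pyrazol-4-yl, on the aromatic carbon next to the ring oxygen, gives a 1.5-fold higher number from compound 2 to compound 4 (0.18 log units; within the scatter), so two different single-ring groups at this place cannot be told apart. Against the two-ring group of compound 1, the same 1H-pyrazol-4-yl group gives a 4.7-fold higher number from compound 1 to compound 4 (0.67 log units; beyond the scatter), which, with a 3.1-fold higher number from compound 1 to compound 2 (0.49 log units; beyond the scatter), sets compound 1 apart from both single-ring compounds at this position. Nothing available explains this difference.

The compounds shown leave open whether chloro, which gave a 2.2-fold lower number from compound 2 to compound 3 (0.35 log units; beyond the scatter) at another place, would act in the same way alongside 1H-pyrazol-4-yl. They also leave open how a carboxylic acid or an amine would compare at this position.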